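This account rests on a few compounds, and the source may have more. Where it says the series, first, only, none or still open, it means among the compounds named here.

Compound 1 `COc1ccc(C2=C(c3cc(OC)c(OC)c(OC)c3)C(=O)C(OC(C)=O)C2)cc1OC(C)C`: > 100 ug/mL
Compound 2 `COc1ccc(C2=C(c3cc(OC)c(OC)c(OC)c3)C(=O)CC2O[SiH2]C(C)(C)C)cc1`: > 100 ug/mL

In an ADME assay on PA-1 cells (Homo sapiens) for cytotoxicity, read by MTT assay, with a stated time of 72 h (a lower number here means a stronger inhibitor, a higher number a weaker inhibitor), compound 2 gives > 100 ug/mL, which is a limit of the assay and not a number. No measured number therefore places compound 2 on the scale. Compound 3 `COC(=O)c1cc(C2=C(c3cc(OC)c(OC)c(OC)c3)C(=O)CC2O[SiH2]C(C)(C)C)ccc1OC` differs from compound 2 in one place: methoxycarbonyl in place of hydrogen on an aromatic carbon. In words, methoxycarbonyl stands in place of hydrogen on an aromatic carbon. Because of the limit of > 100 ug/mL in this assay, at which 2 of the 2 values shown sit, a number no higher from compound 2 to compound 3 (the limit leaves the size open) in this assay is expected to stay within the usual scatter, with no direction foreseen. For compound 3 the estimated value is 100 ug/mL, with an expected range from 50 ug/mL to 200 ug/mL.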

Compound 3, half-maximal inhibitory concentration: > 100 ug/mL
Compound 3: only a limit was reported; the forecaster's own chance of this, stated with the estimate: 75%; the middle value lies on the limit itself.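

In this assay, compound 2 and compound 3 each stand at a limit and not at a number, so the step between them cannot be read: the limit of > 100 ug/mL in this assay, at which 3 of the 3 values shown sit.

From the compounds shown here alone, whether methoxycarbonyl in place of hydrogen on an aromatic carbon changes the true value at all stays open.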